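Carbamoyl in place of hydroxy on the chain carbon

The compounds below may be only part of what the source reports. "The series", "measured", "known", "first", "only" and "open" are said of these compounds alone.

Working notes. Two compounds have numbers in a functional assay on the whole organism (Tail, strain ICR) with Mus musculus as the target, in the tail flick test, with a stated time of 150 min, at a dose of 25 umol/kg by the oral route; a lower number here means a weaker effect, a higher number a stronger effect of the compound at the dose given. Compound 1 `CC[C@H](C)[C@H](NC(=O)CN(c1ncnc2c1ncn2C1CCCCO1)C1CC1)C(=O)OCc1ccccc1` gives 16.4%. Compound 2 `O=C(CN(c1ncnc2c1ncn2C1CCCCO1)C1CC1)N[C@@H](CO)C(=O)OCc1ccccc1` gives 18.3%, and the step of a number 1.9 percentage points higher from compound 1 to compound 2 (within the scatter) leaves the two within the scatter of each other, so compound 2 stands level with compound 1 rather than apart from it.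

Compound 3 `NC(=O)C[C@H](NC(=O)CN(c1ncnc2c1ncn2C1CCCCO1)C1CC1)C(=O)OCc1ccccc1` is not yet measured. It differs from compound 2 by carbamoyl in place of hydroxy on a saturated chain carbon, two bonds along the chain from an amide-type nitrogen and a carbonyl carbon.

Among the measured compounds shown here, only one measured step bears on this change, a number 1.9 percentage points higher from compound 1 to compound 2 (within the scatter), which swapped one group for another on the same chain carbon and moved nothing beyond the scatter. With nothing else to go on, no step beyond the scatter is expected in this assay for the present change either. The expected step is therefore a number 0.3 percentage points lower from compound 2 to compound 3 (within the scatter). Compound 3 is estimated to give 18%, within a range from 8% to 30%.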

Compound 3, a percentage reported as activity, at one dose (the size of the read-out at that dose, not a potency): 21.7%
Compound 3: middle estimate off by 3.7 percentage points, on the low side; measured number inside the range.
By their numbers in this assay, from the lowest: compounds 1, 2 and 3 (each within the scatter of the next).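

In this assay, carbamoyl in place of hydroxy on a saturated chain carbon, two bonds along the chain from an amide-type nitrogen and a carbonyl carbon, gives a number 3.4 percentage points higher from compound 2 to compound 3 (within the scatter), so this change adds a third group at the position without separating it from the others. The wider swap of carbamoylmethyl in place of sec-butyl gives a number 5.3 percentage points higher from compound 1 to compound 3 (within the scatter), and sec-butyl, hydroxymethyl and carbamoylmethyl therefore all stand within the scatter of one another at this dose and time. No measurement is at hand that would explain this result.

Going by these compounds, whether an amine, a carboxylic acid or a longer chain at this carbon would give a step beyond the scatter stays open. On these data alone, the numbers for all three compounds show the size of the effect at this one dose only, and whether any of them would have a stronger or weaker effect at another dose also stays open.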